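The compounds below may be only part of what the source reports. "The series", "measured", "known", "first", "only" and "open" are said of these compounds alone.

Measured so far:
Compound 1 `Cc1cc(-c2ccccc2)ncc1C(=O)Nc1ccc2cccnc2c1` gives 6.7 in an in vitro functional assay on 1321-N1 cells for antagonist activity at transient receptor potential cation channel subfamily V member 1 (Homo sapiens), read by FLIPR and calcium flux; a higher number here means a more potent compound, by a factor of ten per unit of this negative logarithm, a lower number a less potent compound.
Compound 2 `N#Cc1ccc(C(=O)Nc2ccc3cccnc3c2)cn1` gives < 6.7 in this assay, a limit of the assay and not a number.
Compound 3 `Cc1nc(-c2ccc(F)cc2)ccc1C(=O)Nc1ccc2sc(N(C)C)nc2c1` gives < 5.8 in this assay, again a limit of the assay.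

Compound 2 therefore stands only at a limit, one of two such limits among the three values; it cannot be ranked against compound 1. Compound 4 `O=C(Nc1ccc2cccnc2c1)c1ccc(-c2ccccc2F)nc1` differs from compound 2 by 2-fluorophenyl in place of cyano on an aromatic carbon. Going by the values given here, no measured pair shows this step, so its size is a guess. Since compound 1, the closest measured neighbour, gives 6.7, compound 4 is expected to reach 6.8, within 6 to 7.5. The step from compound 2 to compound 4 is then expected to be a number at least 0.10 log units higher from compound 2 to compound 4 (that floor lies within the scatter), if any real value lies under the limit.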

Compound 4, negative logarithm of the antagonist equilibrium constant: 8.7
The estimate for compound 4 lay 1.90 log units below the measured number; measured number above the stated range.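

Compound 2 gives < 6.7 in this assay, a limit of the assay and not a number. Even so, 2-fluorophenyl in place of cyano on this aromatic carbon, next to the ring nitrogen, gives a number at least 2.00 log units higher from compound 2 to compound 4 (beyond the scatter), which shows that this place can carry an added aromatic ring with a large gain in potency. The size of this step is only a floor because compound 2 stands at a limit: the limit of < 6.7 in this assay, at which 1 of the 4 values shown sits.

As far as these compounds go, whether the ring itself or its fluorine carries the gain stays open. So does how an amine or a carboxylic acid on that ring would read out.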